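Swapping halogens on the anilino ring of compound 3

The source may hold more compounds than are shown below. What is called first, only, known or untested is meant among the compounds shown, and "the series" means these compounds.

Three compounds share one core and differ only in the aryl group on a nitrogen on an aromatic ring. Compound 1 `CC(C)c1ccc(Nc2ccc3c(OCCCN4CCN(C)CC4)cccc3n2)cc1` gives 7760 nM in a functional assay on cells (Panel NCI-60 (60 carcinoma cell lines), Homo sapiens) for inhibition, read by sulforhodamine B assay, with a stated time of 48 h; on this read-out higher numbers stand for weaker inhibition of growth and lower numbers for stronger inhibition of growth. Compound 2 `CN1CCN(CCCOc2cccc3nc(Nc4cccc(Cl)c4)ccc23)CC1` gives 1910 nM, and compound 3 `CN1CCN(CCCOc2cccc3nc(Nc4cc(Cl)cc(Cl)c4)ccc23)CC1` gives 1770 nM. Among the three numbers compound 3 holds the lowest, although its separation from compound 2 is within the scatter, as a 1.1-fold lower number from compound 2 to compound 3 (0.03 log units; within the scatter) shows; against compound 1 the gap is real, a 4.4-fold lower number from compound 1 to compound 3 (0.64 log units; beyond the scatter), much like a 4.1-fold lower number from compound 1 to compound 2 (0.61 log units; beyond the scatter).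

Compound 4 `CN1CCN(CCCOc2cccc3nc(Nc4ccc(Cl)c(F)c4)ccc23)CC1` differs from compound 3 in one place: 4-chloro-3-fluorophenyl in place of 3,5-dichlorophenyl on a nitrogen on an aromatic ring. Going by the values given here, the steps that bear on this are those among halogenated aryl groups: moving from compound 2 to compound 3 added one chloro and changed little, and both halogenated compounds sit close together and well away from compound 1. Trading one chlorine for a fluorine while keeping a chlorine is therefore expected to give a step of a 1.1-fold higher number from compound 3 to compound 4 (0.05 log units; within the scatter), none beyond the scatter. Compound 4 is expected to give 2000 nM in this assay, within 900 nM to 4500 nM.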

Compound 4, concentration for 50% growth inhibition: 1820 nM
Compound 4: the middle estimate sits 1.1-fold (0.04 log units) above what was measured, within the range that was stated.
By their numbers in this assay, from the lowest: compounds 3, 4 and 2 (each within the scatter of the next); then compound 1.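

In this assay, the 4-chloro-3-fluorophenyl group does not separate from either chlorinated aryl group (a 1.0-fold higher number from compound 3 to compound 4 (0.01 log units; within the scatter); a 1.0-fold lower number from compound 2 to compound 4 (0.02 log units; within the scatter)), but it stays clear of the 4-isopropylphenyl group (a 4.3-fold lower number from compound 1 to compound 4 (0.63 log units; beyond the scatter)). Across compounds 2, 3 and 4, this position therefore accepts a fluorine alongside a chlorine, and a different halogen arrangement, with no change beyond the scatter, while 4-chloro-3-fluorophenyl shows that a 4-substituted ring need not share the weaker inhibition of compound 1. Nothing measured here explains why these three aryl groups read alike.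

The compounds shown leave open whether this tolerance extends beyond halogens, for example to a nitrile, a methoxy group or an amine on the aryl ring. They also leave open whether a group such as trifluoromethyl at this position would fall with the halogenated compounds or with compound 1.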